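A few compounds are considered here, and "the series" means these few. Any claim that something is new, unique, unknown or untested is made for them only; others in the source may bear on it.

Measured compounds in a functional assay on the whole organism (B cells) with Mus musculus as the target; on this read-out higher numbers stand for larger maximal responses and lower numbers for smaller maximal responses:
compound 1 `Nc1nc(O)c2c(n1)n(C1OC(CO)[C@@H](O)[C@H]1O)c(=O)n2C/C=C/c1ccccc1` with 73%
compound 2 `CC1OC(n2c(=O)n(C)c3c(O)nc(N)nc32)[C@H](O)[C@@H]1O` with 0%
compound 3 `CCn1c(=O)n(C2OC(CO)[C@@H](O)[C@H]2O)c2nc(N)nc(O)c21` with 82%

Compound 3 and compound 1 are close together, a number 9 percentage points higher from compound 1 to compound 3 (within the scatter), so they cannot be told apart; compound 2, which differs from them in more than one place, gives a value far beneath both. Compound 4 `Cn1c(=O)n(C2OC(CO)[C@@H](O)[C@H]2O)c2nc(N)nc(O)c21` comes from compound 3 by the change (hydrogen in place of methyl on a saturated chain carbon bound to an aromatic nitrogen). Among the measured compounds shown here, the only measured step at this position, a number 9 percentage points higher from compound 1 to compound 3 (within the scatter), exchanged a large group for a small one with no change beyond the scatter. Shortening the chain once more is therefore expected to leave the maximal response about where compound 3 has it, so a number 6 percentage points lower from compound 3 to compound 4 (within the scatter). Compound 4 is estimated at 76%, within a range of 55% to 95%.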

Compound 4, largest response reached (reported as maximal response), in percent of the reference or control that the assay uses: 99%
Beside the measured number, compound 4's estimate is 23 percentage points below it; measured number above the stated range.
By their numbers in this assay, from the lowest: compound 2; then compounds 1 and 3 (each within the scatter of the next); then compound 4.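

The group on this aromatic nitrogen does matter in this assay: going from ethyl to methyl gives a number 17 percentage points higher from compound 3 to compound 4 (beyond the scatter), and replacing the 2-phenylethenyl end gives a number 26 percentage points higher from compound 1 to compound 4 (beyond the scatter), even though the earlier step between those two larger groups stayed within the scatter. A second place counts as well, since hydroxy on the saturated chain carbon bound to a saturated ring carbon gives a number 99 percentage points higher from compound 2 to compound 4 (beyond the scatter). No measured evidence explains either effect.

As far as these compounds go, it remains open whether a plain hydrogen on that aromatic nitrogen would keep the response, and whether an amine could stand in for the hydroxy.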